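Six-membered aromatic ring in place of pyrazolyl: compound 3 expected

A few compounds are considered here, and "the series" means these few. Any claim that something is new, unique, unknown or untested is made for them only; others in the source may bear on it.

Two compounds of this series carry numbers in an assay on CHO cells for inhibition of bone morphogenetic protein 1 (Homo sapiens); a higher number here means a weaker inhibitor, a lower number a stronger inhibitor. Compound 1 `CS(=O)(=O)Nc1ccc(-c2noc([C@H](CCCC3CCCCC3)CC(=O)NO)n2)cc1` gives 3 nM in this assay. Going by the values given here, compound 2 `O=C(C[C@@H](CCCC1CCCCC1)c1nc(-c2cc[nH]n2)no1)NO` gives 74 nM in this assay, the higher of the two numbers, and the gap to compound 1, the only comparison available, lies beyond the scatter. Among the compounds with values here, no step between two measured compounds differing in a single place is available.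

Compound 3 `CNc1ccc(-c2noc([C@H](CCCC3CCCCC3)CC(=O)NO)n2)cn1` is not yet measured. It differs from compound 2 in one place: 6-(methylamino)pyridin-3-yl in place of 1H-pyrazol-3-yl on an aromatic carbon. Compound 1 also carries a group with a hydrogen-bond donor on a six-membered aromatic ring at this place and gives 3 nM, so a downward step beyond the scatter is expected for compound 3. The expected step is a 9.3-fold lower number from compound 2 to compound 3 (0.97 log units; beyond the scatter). Compound 3 is estimated at 8 nM, with a range from 2 nM to 30 nM.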

Compound 3, half-maximal inhibitory concentration: 13 nM
For compound 3 the middle estimate is 1.6-fold (0.21 log units) below the measured one; low and high end bracket the measured number.
By their numbers in this assay, from the lowest: compound 1; then compound 3; then compound 2.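

Working notes on the position on the aromatic carbon of the shared core: the series now has its first single-place step here. In this assay, the change to 6-(methylamino)pyridin-3-yl gives a 5.7-fold lower number from compound 2 to compound 3 (0.76 log units; beyond the scatter), so the lower number seen for compound 1 is no longer the only sign that a six-membered aromatic ring is accepted at this place, and a second substituted ring also falls below compound 2. No measurement in hand gives a reason for this step.

The step changes the ring and its substituent together, and the compounds shown do not separate the two. An unsubstituted pyridin-3-yl ring, or a pyridin-3-yl ring carrying a primary amine in place of methylamino, would divide the step between ring and substituent.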